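A few compounds are considered here, and "the series" means these few. Any claim that something is new, unique, unknown or untested is made for them only; others in the source may bear on it.

Measured compounds in an in vitro assay on HEK385-7 cells for displacement of a labelled ligand from prostaglandin D2 receptor 2 (Homo sapiens); a higher number here means a weaker inhibitor, a lower number a stronger inhibitor:
- compound 1 `O=C(O)Cc1sc(C(c2ccccc2)c2ccc(Cl)cc2)nc1-c1ccc(Cl)cc1` gives 45 nM
- compound 2 `COc1ccc(OC)c(-c2nc(C(c3ccccc3)c3ccccc3)sc2CC(=O)O)c1` gives > 105 nM; this is a limit of the assay, not a number
- compound 3 `NS(=O)(=O)c1ccc(-c2nc(C(c3ccc(F)cc3)c3ccc(F)cc3)sc2CC(=O)O)cc1` gives 1500 nM

Of the two numbers shown, compound 3 has the higher one, and its gap to compound 1 lies beyond the scatter. Compound 4 `Cc1cc(-c2nc(C(c3ccc(F)cc3)c3ccc(F)cc3)sc2CC(=O)O)cnc1N` has not been measured. It differs from compound 3 by 6-amino-5-methylpyridin-3-yl in place of 4-sulfamoylphenyl on an aromatic carbon. Among the compounds with values here, no step between measured compounds is available for this change, so the expectation rests on compound 3 alone. The expected step of a 3.0-fold lower number from compound 3 to compound 4 (0.48 log units; beyond the scatter) is toward a lower number, of a size beyond the scatter but uncertain. In this assay compound 4 is estimated at 500 nM, with a range from 100 nM to 3000 nM.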

Compound 4, half-maximal inhibitory concentration: 880 nM
Compound 4: the middle estimate sits 1.8-fold (0.25 log units) below what was measured; the range from low to high includes it.
By their numbers in this assay, from the lowest: compound 1; then compounds 4 and 3 (each within the scatter of the next).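

In this assay, within the data shown here, the only readable step at this position is a 1.7-fold lower number from compound 3 to compound 4 (0.23 log units; within the scatter) and thus separates the two groups no further than repeat measurements would. This position therefore accepts an aromatic ring with one hetero atom as well as one of carbon only, and both groups count the same hydrogen-bond donors and acceptors. Nothing given here bears on the reason for this result.

On these data alone, whether the amino or the methyl group matters stays open, as does the outcome with unsubstituted pyridin-3-yl or 4-methoxyphenyl here. Compound 1 differs from both compounds in more than one place, and its value says nothing separate about this position.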